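The compounds below may be only part of what the source reports. "The series", "measured", "known", "first", "only" and "open" are said of these compounds alone.

Measured so far:
- compound 1 `CC1=CCC[C@H]2[C@](C)(CC3=CC(=O)C(N4CCC[C@H]4C(=O)O)=CC3=O)[C@@H](C)CC[C@]12C`: 60600 nM
- compound 2 `CC1=CCC[C@H]2[C@](C)(CC3=CC(=O)C=CC3=O)[C@@H](C)CC[C@]12C`: 16700 nM

In a functional assay on MDA-MB-453 cells (Homo sapiens) for cytotoxicity, read by MTT assay, with a stated time of 72 h (on this read-out higher numbers stand for weaker inhibition and lower numbers for stronger inhibition), compound 2 gives 16700 nM, the lower of the two numbers, while compound 1 stands higher at 60600 nM. Compound 3 `CC1=CCC[C@H]2[C@](C)(CC3=CC(=O)C=C(N[C@@H](C(=O)O)C(C)C)C3=O)[C@@H](C)CC[C@]12C` differs from compound 2 by one change: (1-carboxy-2-methylpropyl)amino in place of hydrogen on a double-bonded ring carbon. In words, (1-carboxy-2-methylpropyl)amino stands in place of hydrogen on a double-bonded ring carbon.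

For the measured compounds named here, only one measured step bears on this change. It is a 3.6-fold lower number from compound 1 to compound 2 (0.56 log units; beyond the scatter), modest and beyond the scatter, with hydrogen replacing 2-carboxypyrrolidin-1-yl on a double-bonded ring carbon. The change to compound 3 runs the other way, from hydrogen to a carboxy-bearing amino group, so a higher number is expected in this assay, of roughly the same modest size. The guide is loose, since the entering group is not the same one and a single step is all the data offer. The expected step is a 2.7-fold higher number from compound 2 to compound 3 (0.43 log units; beyond the scatter). For compound 3 the estimated value is 45000 nM, with an expected range from 16000 nM to 110000 nM.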

Compound 3, half-maximal inhibitory concentration: 8010 nM
Compound 3: the middle estimate sits 5.6-fold (0.75 log units) above what was measured; the whole stated range lies above it.
By their numbers in this assay, from the lowest: compound 3; then compound 2; then compound 1.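

In this assay, placing (1-carboxy-2-methylpropyl)amino on a double-bonded ring carbon, two ring bonds from the ring atom that bears a large group, gives a 2.1-fold lower number from compound 2 to compound 3 (0.32 log units; beyond the scatter), a modest step but one beyond the scatter. For the compounds shown here, this position therefore takes a substituent of this size with a carboxylic acid in it and still shows a lower number than with hydrogen, whereas the only earlier step, a 3.6-fold lower number from compound 1 to compound 2 (0.56 log units; beyond the scatter), had pointed the opposite way when hydrogen replaced 2-carboxypyrrolidin-1-yl, so a carboxy-bearing amino group does not move the number in one fixed direction across these compounds. Nothing in the data accounts for the direction of this step.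

The compounds shown leave open whether the step belongs to the amino nitrogen or to the carboxylic acid, which a plain amine such as isobutylamino, or the methyl ester of the acid, on this same ring carbon would separate. They also leave open how far the side chain matters, as a longer chain on the amino acid or 2-carboxypyrrolidin-1-yl at this same place could show.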